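From propyl to 4-methylphenyl on an aromatic nitrogen

This account rests on a few compounds, and the source may have more. Where it says the series, first, only, none or still open, it means among the compounds named here.

Measured in a functional assay on HT-29 cells (Homo sapiens) for antiproliferative activity, read by MTT assay, with a stated time of 72 h (a lower number here means a stronger inhibitor, a higher number a weaker inhibitor), with both values limits and not numbers:
- Compound 1 `CCCn1ccnc1-c1cc(OC)c(OC)c(OC)c1`: > 100000 nM
- Compound 2 `COc1cc(-c2nccn2S(=O)(=O)c2ccc(C)cc2)cc(OC)c1OC`: > 100000 nM

Compound 1 has only a limit to show, and it stands at the limit of > 100000 nM in this assay, at which 2 of the 2 values shown sit. Compound 3 `COc1cc(-c2nccn2-c2ccc(C)cc2)cc(OC)c1OC` keeps the core of compound 1 but carries 4-methylphenyl in place of propyl on an aromatic nitrogen. For the measured compounds named here, no step between measured compounds gives a size for this change, so any expectation in this assay is loose. A small move towards stronger inhibition is expected, though a further limit remains quite possible. This expectation starts from compound 1 at its limit of > 100000 nM. The estimate means an at least 1.6-fold lower number from compound 1 to compound 3 (0.22 log units; that floor lies within the scatter), an expected step of uncertain size. For compound 3 the estimated value is 60000 nM, with an expected range from 15000 nM to 100000 nM.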

Compound 3, half-maximal inhibitory concentration: 1600 nM
The estimate for compound 3 lay 38-fold (1.57 log units) above the measured number; the whole stated range lies above it.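

Putting 4-methylphenyl in place of propyl on the aromatic nitrogen gives, in this assay, an at least 62-fold lower number from compound 1 to compound 3 (1.79 log units; beyond the scatter), which shows that a substituent at this position can bring the shared core to a measurable value. Compound 2, in which 4-methylphenyl is attached through a sulfonyl, remains at a limit of > 100000 nM, so the presence of that group alone does not yield a number. Compound 3 is the only one of the three with a number rather than a limit: the limit of > 100000 nM in this assay, at which 2 of the 3 values shown sit.

As far as these compounds go, compound 1 has only a limit, so the full size of the step remains open. From the compounds shown here alone, it also remains open whether the ring alone is enough or its methyl contributes, and how an unsubstituted phenyl, a benzyl or a longer chain on that nitrogen would read in this assay.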